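Working notes: from compound 3 to compound 4

The source may report more compounds than this note shows. Statements on the series, on what has been measured and on what is new or still open speak of the compounds shown alone.

compound 1 `CC(C)=C1C(=O)N(c2ccc(Cl)cc2)N(c2ccc(Cl)cc2)C1=O`: 39000 nM
compound 2 `CCC(C)=C1C(=O)N(c2ccc(Cl)cc2)N(c2ccc(Cl)cc2)C1=O`: 66500 nM
compound 3 `COc1cc(C=C2C(=O)N(c3ccc(Cl)cc3)N(c3ccc(Cl)cc3)C2=O)ccc1O`: 21800 nM

All values come from a functional assay on MGC-803 cells (Homo sapiens) for cytotoxicity, read by MTT assay, with a stated time of 72 h; a lower number here means a stronger inhibitor, a higher number a weaker inhibitor. There, compound 3 at 21800 nM lies within the scatter of compound 1 and beyond the scatter below compound 2.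

Compound 4 `COc1cccc(C=C2C(=O)N(c3ccc(Cl)cc3)N(c3ccc(Cl)cc3)C2=O)c1OC` carries one change, (2,3-dimethoxyphenyl in place of 4-hydroxy-3-methoxyphenyl on a double-bonded chain carbon bound to a double-bonded ring carbon). Among the compounds with values here, the only measured step, a 1.7-fold higher number from compound 1 to compound 2 (0.23 log units; within the scatter), lies at another place, on a saturated chain carbon, so it offers only weak guidance here. Within the data shown here, no measured pair tests this exchange of groups. No shift beyond the scatter is therefore expected, and the estimated step is a 1.2-fold higher number from compound 3 to compound 4 (0.09 log units; within the scatter).

The expected value for compound 4 is 27000 nM, with an estimated range of 11000 nM to 65000 nM.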

Compound 4, half-maximal inhibitory concentration: 29600 nM
Compound 4: the middle estimate sits 1.1-fold (0.04 log units) below what was measured; the measured number falls inside the stated range.
By their numbers in this assay, from the lowest: compounds 3, 4, 1 and 2 (each within the scatter of the next, the first and the last beyond it).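

In this assay, within the data shown here, the exchange on a double-bonded chain carbon bound to a double-bonded ring carbon gives a 1.4-fold higher number from compound 3 to compound 4 (0.13 log units; within the scatter) and is the first step read at this place. 2,3-dimethoxyphenyl in place of 4-hydroxy-3-methoxyphenyl removes the one hydrogen-bond donor and adds one heavy atom, yet the step stays within the scatter. No measured evidence bears on the reason for this result.

Still open, going by these compounds, is whether a phenyl bearing an amine or a carboxylic acid at this place would shift the number beyond the scatter. Also open, on these data alone, is what a single methoxy group or an unsubstituted phenyl would give.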